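Acetyl to Dimethylamino: An Expected Step in Cytotoxicity

A few compounds are considered here, and "the series" means these few. Any claim that something is new, unique, unknown or untested is made for them only; others in the source may bear on it.

Compound 1, `COc1cc(C)cc(-c2c(-c3ccnc(-c4ccc(C(C)=O)cc4)c3)cnn2CC#N)c1`, gives 76% in a functional assay on NCI-H522 cells (Homo sapiens) for cytotoxicity, read by sulforhodamine B assay, with a stated time of 48 h, tested at 100 nM; on this read-out higher numbers stand for a weaker effect at the one concentration tested and lower numbers for a stronger effect.
Compound 2, `Cc1cc(O)cc(-c2nn(CC#N)cc2-c2ccnc(-c3ccc(Oc4ccccc4)cc3)c2)c1`, gives 87% in this assay.

Of the two measured compounds, compound 1 gives the lower number, which on this read-out means the stronger effect at the single concentration tested. The gap to compound 2 is beyond the usual scatter of repeated measurements, so compound 1 stands as the stronger of the pair on the numbers shown. The two compounds differ in more than one place, so no single change can be read from their values.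

Compound 3, `COc1cc(C)cc(-c2c(-c3ccnc(-c4ccc(N(C)C)cc4)c3)cnn2CC#N)c1`, shares the core of compound 1 and differs from it in one place: dimethylamino in place of acetyl on an aromatic carbon. Among the measured compounds shown here, no pair of measured compounds that differ in only this way is available, so the expectation rests on compound 1 alone. The change is expected to bring no step beyond the scatter in this assay, with a slight lean toward a higher number, that is a number 4 percentage points higher from compound 1 to compound 3 (within the scatter). Compound 3 is therefore estimated to give 80% in this assay, within a range from 62% to 98%.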

Compound 3, a percentage reported as activity, at one concentration (the size of the read-out at that concentration, not a potency): -47%
Beside the measured number, compound 3's estimate is 127 percentage points above it; the measured number lies below the stated range.
By their numbers in this assay, from the lowest: compound 3; then compound 1; then compound 2.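

Among the compounds shown here, the step of a number 123 percentage points lower from compound 1 to compound 3 (beyond the scatter) in this assay is the first change in a single place that can be read, since the earlier pair differed in more than one place. It shows that the group on this aromatic carbon of a six-membered aromatic ring of carbon only, para to a large group, can decide the read-out on the core of compound 1. Acetyl and dimethylamino have the same count of heavy atoms and the same counts of hydrogen-bond donors and acceptors, yet the exchange produces a step beyond the scatter, and compound 3, at -47%, falls below zero on this read-out, which compound 1 does not.

Nothing given here bears on the reason for this step.

One exchange cannot tell whether the large step is specific to dimethylamino or would also come with another amine, such as a primary amine, pyrrolidine or morpholine, at this position. The read-out also comes from a single concentration, so it leaves open how compound 3 would compare with compound 1 across a range of concentrations.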